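Swapping Methoxycarbonyl for Trifluoromethyl in a Shared Core

The source may report more compounds than this note shows. Statements on the series, on what has been measured and on what is new or still open speak of the compounds shown alone.

Among the compounds with values here, compound 1 `COC(=O)c1ccc(NC(=O)Nc2cc(C)nc3ccccc23)cc1` is one of two compounds measured in an ADME assay on BJ cells (Homo sapiens) for cytotoxicity, with a stated time of 72 h; on this read-out higher numbers stand for an effect only at larger amounts of compound and lower numbers for an effect already at smaller amounts; there compound 1 gives 21000 nM. Compound 2 `COc1cccc(NC(=O)Nc2cc(C)nc3ccccc23)c1` gives 27000 nM in this assay, a number that lies within the usual scatter of the figure for compound 1, so the two cannot be told apart on this read-out. Compound 3 `Cc1cc(NC(=O)Nc2ccc(C(F)(F)F)cc2)c2ccccc2n1` has not been measured. It differs from compound 1 by trifluoromethyl in place of methoxycarbonyl on an aromatic carbon. Within the data shown here, no measured pair shows this change, so only a small move is expected: a 1.2-fold lower number from compound 1 to compound 3 (0.07 log units; within the scatter), a step not beyond the scatter in either direction. Compound 3 is accordingly estimated at 18000 nM, with a range from 8000 nM to 40000 nM.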

Compound 3, half-maximal effective concentration: > 25000 nM
Compound 3: only a limit was reported (the forecaster's own chance of this, stated with the estimate: 15%); middle value at least 1.3-fold (0.14 log units) from the limit.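

In this assay compound 3 gives only a limit, > 25000 nM. Trifluoromethyl in place of methoxycarbonyl, on an aromatic carbon para to a large group, gives an at least 1.1-fold higher number from compound 1 to compound 3 (0.07 log units; that floor lies within the scatter), the only step read at this position. The size of the step stays unsettled, and one thing bounds the reading: the limit of > 25000 nM in this assay, at which 1 of the 3 values shown sits.

The compounds shown leave open whether this step reaches beyond the scatter. They also leave open what an amine or a carboxylic acid would give on this aromatic carbon.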